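The source may hold more compounds than are shown below. What is called first, only, known or untested is meant among the compounds shown, and "the series" means these compounds.

Measured in a functional assay on MCF7 cells (Homo sapiens) for inhibition, read by fluorescence, with a stated time of 72 h; on this read-out lower numbers stand for stronger inhibition and higher numbers for weaker inhibition:
- compound 1 `CCn1cnc2c(NC(=N)N)nc(N)nc21`: 54300 nM
- compound 2 `CC[C@@H](N)COc1nc(NC(=N)N)c2ncn(C(C)C)c2n1`: > 100000 nM, a limit of the assay
- compound 3 `CC[C@H](CO)Nc1nc(NC(=N)N)c2ncn(C(C)C)c2n1`: 4500 nM

Compound 3, at 4500 nM, has the lowest of the two actual numbers, and compound 1 stands higher at 54300 nM, a gap beyond the scatter. The next compound to be tested, compound 4 `CC(C)[C@H](N)COc1nc(NC(=N)N)c2ncn(C(C)C)c2n1`, carries 2-amino-3-methylbutoxy in place of (1-(hydroxymethyl)propyl)amino on an aromatic carbon. Among the measured compounds shown here, one measured step bears on this change: an at least 22-fold lower number from compound 2 to compound 3 (1.34 log units; beyond the scatter), a large change beyond the scatter, made when (1-(hydroxymethyl)propyl)amino replaced 2-aminobutoxy at the same place. Compound 4 goes the opposite way and returns to a similar aminoalkoxy group, so a large step to a higher number is expected in this assay. The expected change is a 20-fold higher number from compound 3 to compound 4 (1.30 log units; beyond the scatter). The assay may well report only a limit for compound 4. The estimated value for compound 4 is 90000 nM, with an expected range from 30000 nM to 200000 nM.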

Compound 4, half-maximal inhibitory concentration: 3400 nM
Compound 4: the middle estimate sits 26-fold (1.42 log units) above what was measured, outside the stated range (below it).
By their numbers in this assay, from the lowest: compounds 4 and 3 (each within the scatter of the next); then compound 1. At a limit, above all of these: compound 2.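

In this assay, an oxygen-linked chain at this place on the core does not by itself go with a high number, as compound 2 alone had suggested: a 1.3-fold lower number from compound 3 to compound 4 (0.12 log units; within the scatter), so 2-amino-3-methylbutoxy and (1-(hydroxymethyl)propyl)amino cannot be told apart here. With the oxygen link kept, 1-amino-2-methylpropyl in place of 1-aminopropyl on the chain carbon gives an at least 29-fold lower number from compound 2 to compound 4 (1.46 log units; beyond the scatter), which shows that this small change in the chain alone can separate the two oxygen-linked compounds. The value of compound 2 is only a limit: the limit of > 100000 nM in this assay, at which 1 of the 4 values shown sits.

Going by these compounds, it remains open whether a simple alkoxy chain without the amine, or a longer chain such as 2-amino-4-methylpentoxy, would keep numbers of this order. The nitrogen-linked counterpart, (1-(hydroxymethyl)-2-methylpropyl)amino, also remains untested among the compounds shown here.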